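Adding a Methoxy Group to a Simple Chalcone Aniline

This account rests on a few compounds, and the source may have more. Where it says the series, first, only, none or still open, it means among the compounds named here.

Compound 1 `C=C(Br)C(=O)Nc1ccc(C(=O)/C=C/c2cccc(OC)c2OC)cc1` gives 710 nM in an ADME assay on CCRF-CEM cells (Homo sapiens) for antiproliferative activity, with a stated time of 48 h; a lower number here means a stronger inhibitor, a higher number a weaker inhibitor. Compound 2 `C=C(Br)C(=O)Nc1ccc(C(=O)/C=C/c2ccc(OC)c(OC)c2OC)cc1` gives 840 nM in this assay. The step of a 1.2-fold higher number from compound 1 to compound 2 (0.07 log units; within the scatter) comes from methoxy in place of hydrogen on an aromatic carbon. Compound 3 `Nc1ccc(C(=O)/C=C/c2ccccc2)cc1` gives 8500 nM in this assay, the highest number of the three; how its core differs from the core of compound 1 is not broken down here. Compound 4 `COc1ccccc1/C=C/C(=O)c1ccc(N)cc1` differs from compound 3 by methoxy in place of hydrogen on an aromatic carbon. This is the same kind of change as that from compound 1 to compound 2, but the surroundings differ: there the new group sat ortho to a methoxy group, meta to a methoxy group and para to a large group, here it sits ortho to a large group. A small step of a 1.1-fold lower number from compound 3 to compound 4 (0.03 log units; within the scatter) is expected, because the earlier step of a 1.2-fold higher number from compound 1 to compound 2 (0.07 log units; within the scatter) stayed within the scatter. Compound 4 is therefore estimated at 8000 nM, between 3500 nM and 18000 nM.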

Compound 4, half-maximal inhibitory concentration: 6300 nM
The estimate for compound 4 lay 1.3-fold (0.10 log units) above the measured number, within the range that was stated.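

Placing a methoxy group on an aromatic carbon of compound 3 gave a 1.3-fold lower number from compound 3 to compound 4 (0.13 log units; within the scatter) in this assay, so on this core, as on the core of compound 1, the change did not move the number beyond the usual scatter. Set side by side, the two steps cannot be told apart: the same change on two cores in this assay, a 1.2-fold higher number (0.07 log units; within the scatter) from compound 1 to compound 2 and a 1.3-fold lower number (0.13 log units; within the scatter) from compound 3 to compound 4, 1.6-fold (0.20 log units) apart, within the scatter of two such steps. Going by these compounds alone, this shows that the change had no readable effect in either case, but it does not show that this would hold on other cores, since only two cores are compared and the group sits in a different place on each.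

Going by these compounds, it remains open whether a hydroxyl group or an ethoxy group in place of the same hydrogen would shift the number beyond the scatter.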